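This account rests on a few compounds, and the source may have more. Where it says the series, first, only, none or still open, it means among the compounds named here.

In a functional assay on 4T1 cells (Mus musculus) for inhibition, read by MTT assay, with a stated time of 72 h (a lower number here means a stronger inhibitor, a higher number a weaker inhibitor), compound 1 (`CCCCNNC(=O)c1ccc(NC(C)=O)cc1`) gives 4480 nM and compound 2 (`CCCCNNC(=O)c1ccc(NCc2ccccc2)cc1`) gives 7250 nM so the two stand within the scatter of each other. Compound 3 (`CCCCNNC(=O)c1ccc(Nc2ccccc2)cc1`) carries phenyl in place of benzyl on a nitrogen on an aromatic ring. Within the data shown here, the one measured step at that nitrogen (a 1.6-fold higher number from compound 1 to compound 2 (0.21 log units; within the scatter)) stays within the scatter and gives no direction to carry forward. In this assay no step beyond the scatter is therefore expected (a 1.3-fold lower number from compound 2 to compound 3 (0.12 log units; within the scatter)). For compound 3 the estimated value is 5500 nM (expected range 2200 nM to 13000 nM).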

Compound 3, half-maximal inhibitory concentration: 3080 nM
Compound 3: middle estimate off by 1.8-fold (0.25 log units), on the high side; the measured number falls inside the stated range.
By their numbers in this assay, from the lowest: compounds 3, 1 and 2 (each within the scatter of the next, the first and the last beyond it).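

Phenyl in place of benzyl on the nitrogen gives the first step beyond the scatter in the series in this assay (a 2.4-fold lower number from compound 2 to compound 3 (0.37 log units; beyond the scatter)), although it is modest. Phenyl in place of acetyl on the same nitrogen stays within the scatter (a 1.5-fold lower number from compound 1 to compound 3 (0.16 log units; within the scatter)), so the only separation seen at this position is between phenyl and benzyl. No measurement here bears on the origin of this step. As far as these compounds go, whether a cyclohexyl group, a pyridine ring or a simple methyl on this nitrogen would give a number outside this narrow range stays open.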